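A few compounds are considered here, and "the series" means these few. Any claim that something is new, unique, unknown or untested is made for them only; others in the source may bear on it.

Of the compounds shown here, three have been measured in an assay on membranes from brain for binding affinity to neutral cholesterol ester hydrolase 1 (Mus musculus), read by fluorescence, with stated times of 1 h and 30 min; a lower number here means a stronger inhibitor, a higher number a weaker inhibitor: compound 1 `Cc1cnn(C(=O)NCc2ccc(OCc3ccccc3)cc2)c1`, compound 2 `O=C(N1CCCN(Cc2ccc(OCc3ccccc3)cc2)CC1)n1cccn1` and compound 3 `Cc1cnn(C(=O)NCc2ccc(OC(c3ccccc3)c3ccccc3)cc2)c1`. For compound 1 the result is a limit of the assay, > 100000 nM. For compound 2 the result is likewise a limit, > 100000 nM. For compound 3 the result is again a limit, > 100000 nM. For the measured compounds named here, the one step between measured compounds that differ in a single place is a step that the two limits leave unreadable from compound 1 to compound 3; it cannot be read, both of its ends being limits. Compound 3 thus stands where every value shown stands, at the limit of > 100000 nM in this assay, at which 3 of the 3 values shown sit.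

Compound 4 `N#Cc1cnn(C(=O)NCc2ccc(OC(c3ccccc3)c3ccccc3)cc2)c1` differs from compound 3 in one place: cyano in place of methyl on an aromatic carbon. Going by the values given here, no measured step bears on this change, since the only step that exists is unreadable and all three values sit at the same limit. Nothing shown points to a gain or a loss beyond the scatter in this assay. The expected step is therefore a number no higher from compound 3 to compound 4 (the limit leaves the size open), with wide uncertainty. In this assay compound 4 is estimated to give 100000 nM, within a range from 10000 nM to 1000000 nM, and the most likely outcome is once more a limit rather than a number.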

Compound 4, half-maximal inhibitory concentration: > 100000 nM
Compound 4: only a limit was reported; the forecaster's own chance of this, stated with the estimate: 75%; the middle value sits exactly at the limit.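

In this assay compound 4 gives > 100000 nM, which is a limit of the assay and not a number. Compound 3 also sits at a limit, so no step can be read between compound 3 and compound 4, which differ by cyano in place of methyl. Every result shown stands at the same point: the limit of > 100000 nM in this assay, at which 4 of the 4 values shown sit.

The compounds shown leave open what change to the shared core, if any, would give a measurable number in this assay.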